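A few compounds are considered here, and "the series" means these few. Any claim that something is new, unique, unknown or untested is made for them only; others in the source may bear on it.

Measured so far in a functional assay on NIH3T3 cells for agonist activity at Urotensin-2 receptor (Homo sapiens), with a stated time of 5 days; on this read-out higher numbers stand for an effect only at larger amounts of compound and lower numbers for an effect already at smaller amounts:
compound 1 `Cc1ccc(C(CCN(C)C)NC(=O)C#Cc2ccccc2)cc1`: 3090 nM
compound 2 `CN(C)CCC(NC(=O)/C=C/c1ccccc1)c1ccc2ccccc2c1`: 589 nM
compound 3 `Cc1ccc(C(CCN(C)C)NC(=O)/C=C/c2ccccc2)cc1`: 1550 nM

Compound 2 gives the lowest number of the three, and its steps to compound 3 and to compound 1 both lie beyond the scatter. Compound 3 and compound 1 share a core and differ in one place: 2-phenylethynyl in place of 2-phenylethenyl on a carbonyl carbon. That pair gives a 2.0-fold higher number from compound 3 to compound 1 (0.30 log units; within the scatter), a step within the scatter. Compound 2 and compound 3 carry different cores; the difference between the two cores is not broken down here.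

Compound 4 `CN(C)CCC(NC(=O)C#Cc1ccccc1)c1ccc2ccccc2c1` is not yet measured in this assay. It arises from compound 2 by the same change: 2-phenylethynyl in place of 2-phenylethenyl on a carbonyl carbon. The place reads the same word for word in both pairs, so the change is the same, now made on the core of compound 2. Going by the values given here, the expected step is a 2.0-fold higher number from compound 2 to compound 4 (0.31 log units; beyond the scatter), because the one earlier instance of this change gave a 2.0-fold higher number from compound 3 to compound 1 (0.30 log units; within the scatter). Among the compounds with values here, only that single instance supports the expectation. Compound 4 is accordingly expected to give 1200 nM in this assay, with a likely range from 500 nM to 3000 nM.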

Compound 4, half-maximal effective concentration: 457 nM
Compound 4: middle estimate off by 2.6-fold (0.42 log units), on the high side, outside the stated range (below it).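

On the core of compound 2, 2-phenylethynyl in place of 2-phenylethenyl on a carbonyl carbon gives, in this assay, a 1.3-fold lower number from compound 2 to compound 4 (0.11 log units; within the scatter). Set beside the earlier instance, the two steps cannot be told apart: the same change on two cores in this assay, a 2.0-fold higher number (0.30 log units; within the scatter) from compound 3 to compound 1 and a 1.3-fold lower number (0.11 log units; within the scatter) from compound 2 to compound 4, 2.6-fold (0.41 log units) apart, within the scatter of two such steps. Both steps lie within the scatter, so this pair of cores gives no sign that the change acts differently on one core than on the other, but it also does not show that the change has any real effect in either direction, and two cores are too few to set a general rule for the series.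

Still open, from the compounds shown here alone, is how a saturated 2-phenylethyl group on the same carbonyl carbon would compare with the 2-phenylethenyl and 2-phenylethynyl pairs. The compounds shown also leave open whether the same swap stays this small on a third core, for instance one carrying a primary amine in place of the dimethylamino group.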